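A few compounds are considered here, and "the series" means these few. Any claim that something is new, unique, unknown or untested is made for them only; others in the source may bear on it.

Compound 2 `Cc1ccccc1C1C(C#N)=C(N)OC(c2c[nH]c3ccccc23)=C1C#N` gives only a limit in a functional assay (a higher number here means a weaker inhibitor, a lower number a stronger inhibitor), > 1000 ug/mL, and this is the limit of > 1000 ug/mL in this assay, at which 1 of the 3 values shown sits. Two relatives with the same core give numbers in this assay: compound 3 `COc1ccc(C2C(C#N)=C(N)OC(c3c[nH]c4ccccc34)=C2C#N)cc1` gives 859 ug/mL, and compound 1 `COc1cc(Br)c(C2C(C#N)=C(N)OC(c3c[nH]c4ccccc34)=C2C#N)cc1OC` gives 880 ug/mL. Compound 4 `N#CC1=C(N)OC(c2c[nH]c3ccccc23)=C(C#N)C1c1ccc(F)cc1`, not yet measured, carries 4-fluorophenyl in place of 2-methylphenyl on a saturated ring carbon. For the measured compounds named here, the one measured step that bears on this change is an at least 1.1-fold lower number from compound 2 to compound 3 (0.06 log units; that floor lies within the scatter), where 4-methoxyphenyl replaces the same 2-methylphenyl on that carbon. Compound 4 loses the 2-methylphenyl in the same way, so a similarly small move toward a lower number is expected in this assay, and nothing larger than the scatter is foreseen. The expected step is an at least 1.1-fold lower number from compound 2 to compound 4 (0.04 log units; that floor lies within the scatter). For compound 4 the estimated value is 900 ug/mL, with an expected range from 600 ug/mL to 1300 ug/mL.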

Compound 4, half-maximal inhibitory concentration: 960 ug/mL
The estimate for compound 4 lay 1.1-fold (0.03 log units) below the measured number; the range from low to high includes it.
By their numbers in this assay, from the lowest: compounds 3, 1 and 4 (each within the scatter of the next). At a limit, above all of these: compound 2.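

With a second group on this saturated ring carbon, the change from 2-methylphenyl to 4-fluorophenyl gives an at least 1.0-fold lower number from compound 2 to compound 4 (0.01 log units; that floor lies within the scatter). That step can be read only as a floor, and how much further it goes is not known: the limit of > 1000 ug/mL in this assay, at which 1 of the 4 values shown sits.

Fluoro in place of methoxy on an aromatic carbon gives a 1.1-fold higher number from compound 3 to compound 4 (0.05 log units; within the scatter), so this assay does not separate the 4-fluorophenyl group from the 4-methoxyphenyl group, which the earlier compounds could not show.

From the compounds shown here alone, whether any group at this position can move the number beyond the scatter remains open, since the groups compared here are all substituted phenyl rings. Going by these compounds, the effect of a carboxylic acid or an amine on the aromatic ring, or of an open alkyl chain on the saturated carbon in place of the ring, also remains open.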